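The source may report more compounds than this note shows. Statements on the series, on what has been measured and on what is new or still open speak of the compounds shown alone.

The measured compounds:
- compound 1, `Cc1ccc2nc(C(=O)Nc3c(F)cc(-c4cccc(F)c4)cc3F)c(C)c(O)c2c1`: in a functional assay on A-375 cells (Homo sapiens) for antiproliferative activity, read by MTT assay, with a stated time of 24 h, tested at 0.41 ug/mL (on this read-out higher numbers stand for a stronger effect at the one concentration tested and lower numbers for a weaker effect), compound 1 gives 1.35%
- compound 2, `Cc1c(C(=O)Nc2c(F)cc(-c3cccc(F)c3)cc2F)nc2ccc(F)cc2c1O`: compound 2 gives 0.86%
- compound 3, `Cc1ccc2nc(C(=O)Nc3c(F)cc(-c4cccc(F)c4)cc3F)c(C)c(C(=O)O)c2c1`: compound 3 gives 1.53%

All three numbers are small and close together. Among the compounds with values here, compound 3 stands highest of the three, but its nearest neighbour is compound 1, with a number 0.2 percentage points higher from compound 1 to compound 3 (within the scatter), and compound 2 sits only a little further off, so no compound can be called the stronger one on these numbers.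

Compound 4, `Cc1c(C(=O)Nc2c(F)cc(-c3cccc(F)c3)cc2F)nc2ccc(F)cc2c1C(=O)O`, is not yet measured. It is derived from compound 3 by the change (fluoro in place of methyl on an aromatic carbon). Within the data shown here, the one measured step that bears on this change is the same exchange made on the hydroxy series, where a number 0.5 percentage points lower from compound 1 to compound 2 (within the scatter). That step was within the scatter, and the other measured step, the exchange of hydroxy for carboxy, a number 0.2 percentage points higher from compound 1 to compound 3 (within the scatter), was also within the scatter. Among the measured compounds shown here, nothing among the measured compounds therefore points to a move beyond the scatter in this assay when the same exchange is applied to compound 3.

On that basis compound 4 is expected to give about 1%, within a range of -5% to 7%. The expected step of a number 0.5 percentage points lower from compound 3 to compound 4 (within the scatter) is estimated to stay within the scatter.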

Compound 4, a percentage reported as inhibition, at one concentration (the size of the read-out at that concentration, not a potency): 3.02%
Estimate against measurement, compound 4: 2 percentage points below; low and high end bracket the measured number.
By their numbers in this assay, from the lowest: compounds 2, 1, 3 and 4 (each within the scatter of the next).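

With the carboxy group in place of hydroxy, fluoro in place of methyl on an aromatic carbon gives a number 1.5 percentage points higher from compound 3 to compound 4 (within the scatter), so this exchange in this assay has now been read on two cores, and neither reading leaves the scatter: the same change on two cores in this assay, a number 0.5 percentage points lower (within the scatter) from compound 1 to compound 2 and a number 1.5 percentage points higher (within the scatter) from compound 3 to compound 4, 2 percentage points apart, within the scatter of two such steps

Carboxy in place of hydroxy can now also be read on the fluoro-bearing core, where it gives a number 2.2 percentage points higher from compound 2 to compound 4 (within the scatter), and this reading likewise stays within the scatter: the same change on two cores in this assay, a number 0.2 percentage points higher (within the scatter) from compound 1 to compound 3 and a number 2.2 percentage points higher (within the scatter) from compound 2 to compound 4, 2 percentage points apart, within the scatter of two such steps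

Together, the four compounds show no effect of either change that can be told from the scatter, and no sign that the outcome of one change depends on the group present at the other place.

As far as these compounds go, it remains open whether another group on this aromatic carbon, meta to a fused ring and para to a fused ring, such as chloro, methoxy or an amine, or an ester or amide in place of the carboxy group, would move the number beyond the scatter. Because the read-out comes from a single concentration, the compounds also leave open how they would compare in potency.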